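From Methyl to Chloro: Estimating Compound 4

This account rests on a few compounds, and the source may have more. Where it says the series, first, only, none or still open, it means among the compounds named here.

Of the compounds shown here, three built on one shared core have been tested in a functional assay on PC-9 cells (Homo sapiens) for antiproliferative activity, read by MTT assay; on this read-out higher numbers stand for weaker inhibition and lower numbers for stronger inhibition. Compound 1 `C#CCSc1nc(Sc2nccs2)c(C#N)c(-c2ccc(C)cc2)n1` gives 1110 nM, the lowest of the two numbers reported. Compound 2 `C#CCSc1nc(Sc2nncs2)c(C#N)c(-c2cc(OC)c(OC)c(OC)c2)n1` gives 7960 nM, a number that stands above that of compound 1 by more than the usual scatter. Compound 3 `C#CCSc1nc(Sc2nc(C)c(C)s2)c(C#N)c(-c2cc(OC)c(OC)c(OC)c2)n1` reaches only the limit of this assay (the limit of > 20000 nM in this assay, at which 1 of the 3 values shown sits), reported as > 20000 nM. Within the data shown here, the single measured step that alters one place, an at least 2.5-fold higher number from compound 2 to compound 3 (0.40 log units; beyond the scatter), concerns the group on a sulfur, not the six-membered ring of carbon only.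

Compound 4 `C#CCSc1nc(Sc2nccs2)c(C#N)c(-c2ccc(Cl)cc2)n1` has not yet been measured. It differs from compound 1 by chloro in place of methyl on an aromatic carbon. Among the measured compounds shown here, no measured step touches this position, so the data give no direction for the change. The number for compound 4 is expected to stay close to that of compound 1, the estimated step of a 1.1-fold lower number from compound 1 to compound 4 (0.05 log units; within the scatter) lying within the scatter. Compound 4 is estimated at 1000 nM, in a range from 350 nM to 3000 nM.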

Compound 4, half-maximal inhibitory concentration: 4130 nM
The estimate for compound 4 lay 4.1-fold (0.62 log units) below the measured number, and the stated range ends below it.
By their numbers in this assay, from the lowest: compound 1; then compounds 4 and 2 (each within the scatter of the next). At a limit, above all of these: compound 3.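

In this assay, among these compounds, the single swap of 4-methylphenyl to 4-chlorophenyl gives a 3.7-fold higher number from compound 1 to compound 4 (0.57 log units; beyond the scatter). This position on the six-membered aromatic ring of carbon only is therefore not silent: exchanging one heavy atom here moves the number beyond the scatter, and with the rest of compound 1 unchanged, methyl gives the stronger inhibition of the two groups. Nothing in the data shown bears on why the number rises with chloro.

On these data alone, whether fluoro, an amine or a carboxylic acid in this same place would give a lower or a higher number remains open. As far as these compounds go, it is also open whether chloro in place of methyl would bring a step of similar size with a different group on the sulfur.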